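This account rests on a few compounds, and the source may have more. Where it says the series, first, only, none or still open, it means among the compounds named here.

Three compounds have been measured in a functional assay on MDA-MB-435 cells (Homo sapiens) for inhibition, read by sulforhodamine B assay, with a stated time of 48 h; on this read-out lower numbers stand for stronger inhibition of growth and higher numbers for weaker inhibition of growth:

Compound 3, `COc1cc(-c2nn(-c3cccc(NC(=O)c4cccc(C(F)(F)F)c4)c3)cc2-c2ccncc2)ccc1Cl`: 705 nM
Compound 2, `COc1cc(-c2nn(-c3cccc(NC(=O)Nc4cc(C(F)(F)F)cc(C(F)(F)F)c4)c3)cc2-c2ccncc2)ccc1Cl`: 886 nM
Compound 1, `O=C(Nc1cccc(-n2cc(-c3ccncc3)c(-c3ccc(Cl)c(O)c3)n2)c1)Nc1cccc(C(F)(F)F)c1`: 1490 nM

Compound 3 gives the lowest of these three numbers, but its value sits within the usual scatter of compound 2, so the two cannot be told apart; only the gap to compound 1 lies beyond the scatter. All three share the same core and differ in the group hanging from the amide or urea on the outer ring.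

Compound 4, `COc1cc(-c2nn(-c3cccc(NC(=O)c4ccccc4)c3)cc2-c2ccncc2)ccc1Cl`, is the next step from compound 3. The change is hydrogen in place of trifluoromethyl on an aromatic carbon of a six-membered aromatic ring of carbon only, meta to a large group. Put more broadly, the 3-(trifluoromethyl)phenyl becomes a plain phenyl, and the (3-(trifluoromethyl)phenyl)carbonyl becomes a benzoyl.

Going by the values given here, none of the measured pairs shows exactly this change, so its size can only be guessed. Stripping a sizeable group in this way most often costs some activity, so in this assay a modest rise in the number, of about the scatter or a little beyond, is expected: the step of a 1.8-fold higher number from compound 3 to compound 4 (0.27 log units; within the scatter) is the estimate. Compound 4 is accordingly expected to give 1300 nM, with a likely range from 500 nM to 3500 nM.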

Compound 4, concentration for 50% growth inhibition: 189 nM
Beside the measured number, compound 4's estimate is 6.9-fold (0.84 log units) above it; measured number below the stated range.
By their numbers in this assay, from the lowest: compound 4; then compounds 3, 2 and 1 (each within the scatter of the next, the first and the last beyond it).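

In this assay, going by these compounds alone, this is the first change that can be read in one place alone: replacing trifluoromethyl with hydrogen, so that the 3-(trifluoromethyl)phenyl becomes a plain phenyl, gives a 3.7-fold lower number from compound 3 to compound 4 (0.57 log units; beyond the scatter). The trifluoromethyl group is therefore not needed for growth inhibition in this pair, and compound 4, with the bare benzoyl, does better than compound 3, which carries the larger group. Nothing available here accounts for why the number falls with this change.

The compounds shown leave open whether hydrogen itself is the best choice on this aromatic carbon, or whether a small group such as a methyl, a methoxy or a single fluorine would fall nearer to compound 4 or to compound 3. Within the data shown here, they also leave open whether the same swap would give a step of similar size on a urea such as compound 2, since only one amide pair can be read so far.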